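The source may report more compounds than this note shows. Statements on the series, on what has been measured and on what is new or still open speak of the compounds shown alone.

Measured so far:
- compound 1 `COc1cccc(NC(=O)N[C@H]2CC[C@H](Oc3ccc(F)cc3)CC2)c1`: in a functional assay on CRL2813 cells (Homo sapiens) for cytotoxicity, read by sulforhodamine B assay, with a stated time of 5 days (on this read-out higher numbers stand for weaker inhibition and lower numbers for stronger inhibition), compound 1 gives 14000 nM
- compound 2 `O=C(Nc1cccc(C(F)(F)F)c1)N[C@H]1CCC[C@H](Oc2ccc(C(F)(F)F)cc2)C1`: in this assay compound 2 gives 3800 nM

Of the two numbers seen, compound 1 stands highest; the nearest is compound 2, whose number is lower by a gap beyond the usual scatter. For the measured compounds named here, no pair among the measured compounds differs in a single place, so no single change has a measured step attached to it.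

Compound 3 `O=C(Nc1cccc([N+](=O)[O-])c1)N[C@H]1CC[C@H](Oc2ccc(F)cc2)CC1` is the compound still to be measured. It differs from compound 1 as follows: nitro in place of methoxy on an aromatic carbon. Going by the values given here, since no measured pair shows what this exchange does, the size of the step is open. A modest step is expected, tending toward a lower number but likely within the scatter, so a 1.8-fold lower number from compound 1 to compound 3 (0.24 log units; within the scatter) is the estimated change. On this basis compound 3 is expected to give about 8000 nM, with a range from 2500 nM to 25000 nM.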

Compound 3, half-maximal inhibitory concentration: 6700 nM
The estimate for compound 3 lay 1.2-fold (0.08 log units) above the measured number; the measured number falls inside the stated range.
By their numbers in this assay, from the lowest: compounds 2 and 3 (each within the scatter of the next); then compound 1.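

In this assay nitro in place of methoxy on this aromatic carbon gives a 2.1-fold lower number from compound 1 to compound 3 (0.32 log units; beyond the scatter) and is the only single change with a measured step among the compounds shown. The number therefore responds to what sits at this position, although the step is modest and rests on this one pair. Nothing measured here bears on why the exchange moves the number.

Going by these compounds, what other groups would do at this same aromatic carbon stays open, for instance an amine, a carboxylic acid or a nitrile, and so does whether the order of methoxy and nitro would hold on another core. On these data alone, it is also open whether nitro would give a step of similar size at another carbon of this six-membered aromatic ring.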